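Chloro for Methyl on the Sulfonyl-Side Aromatic Ring

This account rests on a few compounds, and the source may have more. Where it says the series, first, only, none or still open, it means among the compounds named here.

Of the compounds shown here, two have been measured in a functional assay on B16-F10 cells (Mus musculus) for antiproliferative activity, read by ELISA and MTT assay, with a stated time of 48 h; a lower number here means a stronger inhibitor, a higher number a weaker inhibitor. Compound 1 `O=C(/C=C/c1ccc(Cl)cc1)NS(=O)(=O)c1ccc(Cl)cc1` gives 2.5 ug/mL. Compound 2 `Cc1ccc(S(=O)(=O)NC(=O)/C=C/c2ccc(Br)cc2)cc1` gives 12.1 ug/mL, the highest of the two numbers, and its gap to compound 1 lies beyond the usual scatter. Compound 3 `O=C(/C=C/c1ccc(Br)cc1)NS(=O)(=O)c1ccc(Cl)cc1` differs from compound 2 by chloro in place of methyl on an aromatic carbon, read one bond further out as 4-methylphenyl to 4-chlorophenyl. Compound 1 already carries that 4-chlorophenyl and gives 2.5 ug/mL. On this ground, compound 3 is expected to take a step of a 2.7-fold lower number from compound 2 to compound 3 (0.43 log units; beyond the scatter) toward a lower number. Compound 3 is estimated at 4.5 ug/mL, within a range from 1.8 ug/mL to 12 ug/mL.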

Compound 3, half-maximal inhibitory concentration: 5.2 ug/mL
Compound 3: the middle estimate sits 1.2-fold (0.06 log units) below what was measured; the measured number falls inside the stated range.
By their numbers in this assay, from the lowest: compound 1; then compound 3; then compound 2.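

Among these compounds, compound 3 gives the first reading of a single change at this position: 4-methylphenyl to 4-chlorophenyl alone brings a 2.3-fold lower number from compound 2 to compound 3 (0.37 log units; beyond the scatter) in this assay. With the 4-chlorophenyl kept, bromo in place of chloro on an aromatic carbon gives a 2.1-fold higher number from compound 1 to compound 3 (0.32 log units; beyond the scatter), so each single change is modest but beyond the scatter. Nothing available explains either step. Going by these compounds, how an amine or a methoxy group in place of the chloro would read remains open, and one step at this position cannot show a trend.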